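The compounds below may be only part of what the source reports. "The series", "measured", "known", "first", "only" and "open" are said of these compounds alone.

Compound 1 `O=C(/C=C/c1cccc(Cl)c1Cl)Nc1cc2c(Nc3ccc(F)c(Cl)c3)ncnc2cc1O[C@H]1CCOC1` is one of two related molecules with a number in a functional assay on A549 cells (Homo sapiens) for cytotoxicity, read by MTT assay, with a stated time of 72 h; a lower number here means a stronger inhibitor, a higher number a weaker inhibitor. In this test, compound 1 gives 23200 nM, and compound 2 `COc1cc2ncnc(Nc3ccc(F)c(Cl)c3)c2cc1NC(=O)/C=C/c1ccccc1[N+](=O)[O-]` gives 33300 nM. These two values lie within the usual scatter of each other, so compound 1 cannot be separated from compound 2.

Compound 3 `COc1ccc(/C=C/C(=O)Nc2cc3c(Nc4ccc(F)c(Cl)c4)ncnc3cc2O[C@H]2CCOC2)c(OC)c1OC` keeps the core of compound 1 but carries 2,3,4-trimethoxyphenyl in place of 2,3-dichlorophenyl on a double-bonded chain carbon bound to a double-bonded chain carbon. Within the data shown here, no two measured compounds differ in only one place, so the data do not show how a change of this kind moves the number. The best available guide is the value of compound 1, 23200 nM, which sits close to the value of compound 2, 33300 nM. A step beyond the scatter is therefore not expected in this assay, and no firm direction can be given. The estimated change is a 1.1-fold higher number from compound 1 to compound 3 (0.03 log units; within the scatter), which is small. For compound 3, the expected value is 25000 nM, with a likely range from 10000 nM to 60000 nM.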

Compound 3, half-maximal inhibitory concentration: 70 nM
Compound 3: middle estimate off by 360-fold (2.55 log units), on the high side; measured number outside the range, below it.
By their numbers in this assay, from the lowest: compound 3; then compounds 1 and 2 (each within the scatter of the next).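

In this assay, putting 2,3,4-trimethoxyphenyl in place of 2,3-dichlorophenyl on a double-bonded chain carbon bound to a double-bonded chain carbon gives a 330-fold lower number from compound 1 to compound 3 (2.52 log units; beyond the scatter), a large step. This is the first change shown in one place only, and it reveals that the group at this position can move the number a long way while the rest of the molecule stays the same, something the two earlier compounds could not show, as their values lie within the scatter of each other. The entering group carries 3 hydrogen-bond acceptors and the leaving group 0, but no measurement shown explains why the number moves.

This single exchange removes both chlorine atoms and adds all three methoxy groups at once, so it remains open which part of the change accounts for the step. Among these compounds, a phenyl group with only one methoxy group, or with a hydroxyl group or an amine in its place, would help separate these contributions, and the same exchange on a different core would test whether the step carries over.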